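Second Methyl on the Aryl Ketone of a Chalcone Series

This account rests on a few compounds, and the source may have more. Where it says the series, first, only, none or still open, it means among the compounds named here.

Compound 1 `COc1cc(C(=O)/C=C/c2cc(-c3cc(OC)c(OC)c(OC)c3)n3nc(-c4ccccc4)cc3n2)cc(OC)c1OC`, 24300 nM
Compound 2 `COc1cc(-c2cc(/C=C/C(=O)c3ccc(C)cc3)nc3cc(-c4ccccc4)nn23)cc(OC)c1OC`, 23900 nM

Going by the values given here, in a functional assay on MDA-MB-231 cells (Homo sapiens) for antiproliferative activity, read by MTT assay, with a stated time of 24 h (a higher number here means a weaker inhibitor, a lower number a stronger inhibitor), compound 2 gives the lower of the two numbers, yet the only measured step, a 1.0-fold lower number from compound 1 to compound 2 (0.01 log units; within the scatter), lies within the scatter, so the two compounds cannot be ordered. Compound 3 `COc1cc(-c2cc(/C=C/C(=O)c3ccc(C)c(C)c3)nc3cc(-c4ccccc4)nn23)cc(OC)c1OC` differs from compound 2 by methyl in place of hydrogen on an aromatic carbon. Among the compounds with values here, no measured step involves a change on this ring, and the one step that was measured shows no shift beyond the scatter; an expected change of a 1.0-fold higher number from compound 2 to compound 3 (0.00 log units; within the scatter) is therefore assumed. Compound 3 is expected to give 24000 nM, in a range from 10000 nM to 55000 nM.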

Compound 3, half-maximal inhibitory concentration: 13500 nM
Compound 3: middle estimate off by 1.8-fold (0.25 log units), on the high side, and the stated range covers the measured number.
By their numbers in this assay, from the lowest: compounds 3, 2 and 1 (each within the scatter of the next).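

Going by these compounds alone, the first measured change on this ring, a methyl on the carbon ortho to a methyl group and meta to a large group, reads as a 1.8-fold lower number from compound 2 to compound 3 (0.25 log units; within the scatter) in this assay and cannot be ordered. The wider exchange for 3,4-dimethylphenyl reads as a 1.8-fold lower number from compound 1 to compound 3 (0.26 log units; within the scatter) and so also leaves the three aryl ketones unresolved. No measured evidence bears on this result.

The compounds shown leave open whether an amine or a carboxylic acid on this ring, or a longer chain in place of the added methyl, would give a step beyond the scatter.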